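Methoxy added to the benzylamine of the shared core

The source may hold more compounds than are shown below. What is called first, only, known or untested is meant among the compounds shown, and "the series" means these compounds.

Compound 1 `COc1ccc(CNc2nc([SeH])nc3ccccc23)cc1`: in an ADME assay on BEAS-2B cells (Homo sapiens) for cytotoxicity, read by MTT assay, with a stated time of 72 h (on this read-out higher numbers stand for weaker inhibition of growth and lower numbers for stronger inhibition of growth), a limit, > 100000 nM.
Compound 2 `CSc1nc(NCc2ccccc2)c2ccccc2n1`: in this assay gives 88200 nM.

For the measured compounds named here, compound 2 carries the only measured number in this assay. Going by the values given here, the one further value belongs to compound 1, which sits at the limit of > 100000 nM in this assay, at which 1 of the 2 values shown sits. Compound 3 `COc1ccc(CNc2nc(SC)nc3ccccc23)cc1` differs from compound 2 by methoxy in place of hydrogen on an aromatic carbon. Among the compounds with values here, no step between measured compounds is available. Compound 1 also carries that methoxy and reports only a limit. The change is expected to stay within the scatter, estimated as a 1.0-fold higher number from compound 2 to compound 3 (0.01 log units; within the scatter). Compound 3 is estimated at 90000 nM, expected between 40000 nM and 200000 nM.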

Compound 3, concentration for total growth inhibition: 96200 nM
Compound 3: the middle estimate sits 1.1-fold (0.03 log units) below what was measured; measured number inside the range.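

Methoxy in place of hydrogen, para to a large group, now has a measured step in this assay: a 1.1-fold higher number from compound 2 to compound 3 (0.04 log units; within the scatter), so this change leaves the read-out where it was, within the scatter. Compound 1 remains a limit and not a number: the limit of > 100000 nM in this assay, at which 1 of the 3 values shown sits.
Replacing its selenium atom with the group of 2 heavy atoms gives an at least 1.0-fold lower number from compound 1 to compound 3 (0.01 log units; that floor lies within the scatter), so that exchange has a floor but no measured size.

Going by these compounds, whether an amine or a carboxylic acid at this carbon would also stay within the scatter of compound 2 remains open. On these data alone, the true size of the selenium exchange also remains open.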